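Cytotoxicity of an Ester-Bearing Analogue Before Measurement

The source may hold more compounds than are shown below. What is called first, only, known or untested is meant among the compounds shown, and "the series" means these compounds.

In an ADME assay on Huh-7 cells (Homo sapiens) for cytotoxicity (on this read-out higher numbers stand for lower toxicity in this test and lower numbers for higher toxicity in this test), compound 1 `Cc1ccccc1CNc1nn(-c2ccc(F)cc2F)cc1CNCCN1CCN(C)CC1` is recorded only as a limit, > 20000 nM. Compound 2 `Cc1ccccc1-c1nn(Cc2ccc(F)cc2)cc1CNCCN1CCN(C)CC1` likewise reaches only a limit in this assay, > 20000 nM. Going by the values given here, compound 1 therefore stands at the limit itself, in the same position as the one other value shown, and no step between measured compounds can be drawn; what the numbers give is the limit of > 20000 nM in this assay, at which 2 of the 2 values shown sit. Compound 3 `COC(=O)c1ccc(-c2nn(-c3ccc(F)cc3F)cc2CNCCN2CCN(C)CC2)cc1` remains to be measured in this assay. It differs from compound 1 by 4-(methoxycarbonyl)phenyl in place of (2-methylbenzyl)amino on an aromatic carbon. Without a measured step to rest on, the move to the new compound is expected to stay within the scatter of this assay, and the estimated step is a step that the limit leaves unreadable from compound 1 to compound 3. Compound 3 is expected to land at or near the limit, with a half-maximal cytotoxic concentration estimated at 25000 nM, between 10000 nM and 60000 nM, and with a good chance that this assay again reports only a limit rather than a number.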

Compound 3, half-maximal cytotoxic concentration: > 20000 nM
Compound 3 was reported as a limit (the forecaster's own chance of this, stated with the estimate: 70%); the middle value is on the limit's open side.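

In this assay compound 3 gives > 20000 nM as a limit of the assay, not a number. Compound 1 is also recorded only as a limit, so no step can be read from compound 1 to compound 3. The compounds shown leave open what concentration would actually be cytotoxic for any of them, as all rest on one limit: the limit of > 20000 nM in this assay, at which 3 of the 3 values shown sit.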